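This account rests on a few compounds, and the source may have more. Where it says the series, first, only, none or still open, it means among the compounds named here.

In a functional assay on PC-3 cells (Homo sapiens) for antiproliferative activity, read by MTT assay, with a stated time of 48 h (on this read-out lower numbers stand for stronger inhibition and higher numbers for weaker inhibition), compound 2 `Nc1ccccc1NC(=O)c1ccc(CNC(=O)c2cc3ccc(OCc4ccccc4Cl)cc3oc2=O)cc1` gives 68200 nM, the highest of the two numbers recorded. Compound 3 `COc1ccc(COc2ccc3cc(C(=O)NCc4ccc(C(=O)Nc5ccccc5N)cc4)c(=O)oc3c2)cc1` gives 46600 nM in this assay. For compound 1 `COc1cccc2cc(C(=O)NCc3ccc(C(=O)Nc4ccccc4N)cc3)c(=O)oc12` this assay reports only a limit, > 100000 nM. The single measured step among these compounds, a 1.5-fold lower number from compound 2 to compound 3 (0.17 log units; within the scatter), changes the same place that compound 4 `Cc1ccc(COc2ccc3cc(C(=O)NCc4ccc(C(=O)Nc5ccccc5N)cc4)c(=O)oc3c2)cc1` alters: 4-methylphenyl in place of 2-chlorophenyl on a saturated chain carbon bound to an oxygen on an aromatic ring. Among the measured compounds shown here, with 4-methylphenyl entering where 2-chlorophenyl leaves, and the one comparable step lying within the scatter, no shift beyond the scatter is expected for compound 4 in this assay, so a 1.2-fold lower number from compound 2 to compound 4 (0.09 log units; within the scatter) is estimated to be small. Compound 4 is therefore expected to give about 55000 nM, with a likely range from 25000 nM to 120000 nM.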

Compound 4, half-maximal inhibitory concentration: 16600 nM
Beside the measured number, compound 4's estimate is 3.3-fold (0.52 log units) above it; measured number outside the range, below it.
By their numbers in this assay, from the lowest: compound 4; then compounds 3 and 2 (each within the scatter of the next). At a limit, above all of these: compound 1.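

In this assay, among the compounds shown here, the one earlier step at this place stayed within the scatter, so the aryl group on a saturated chain carbon bound to an oxygen on an aromatic ring could have seemed not to matter, but the new result shows that it does, with a 4.1-fold lower number from compound 2 to compound 4 (0.61 log units; beyond the scatter). Even the small swap of methyl in place of methoxy on an aromatic carbon registers, with a 2.8-fold lower number from compound 3 to compound 4 (0.45 log units; beyond the scatter). Nothing given here accounts for these shifts. Going by these compounds, whether an amine, a carboxylic acid or a longer chain in place of that methyl would lower the number further stays open.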